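A few compounds are considered here, and "the series" means these few. Any claim that something is new, unique, unknown or untested is made for them only; others in the source may bear on it.

Measured so far in an ADME assay on S9 fraction from liver (Rattus norvegicus) for metabolic stability, read by LC-MS, using NADPH, with a stated time of 90 min, tested at 5 uM; a lower number here means that less of the compound is left, a higher number that more of the compound is left:
- compound 1 `O=C(NO)c1cc(F)c(Cn2nnc(-c3ccco3)n2)c(F)c1` at 68%
- compound 2 `Cn1c(Sc2c(F)cc(C(=O)NO)cc2F)nnc1-c1cccs1` at 71%

Compound 2 at 71% lies within the usual scatter of compound 1 at 68% in this assay and the two values cannot be told apart. Neither compound can be placed ahead of the other on these numbers.

The next compound to be read is compound 3 `Cn1c(Sc2c(F)cc(C(=O)NO)cc2F)nnc1-c1cccnn1` which carries pyridazin-3-yl in place of thiophen-2-yl on an aromatic carbon of a five-membered aromatic ring with 3 nitrogen. The counted difference is pyridazin-3-yl in place of thiophen-2-yl on an aromatic carbon and the rest of the structure stays as in compound 2.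

Among the measured compounds shown here, no measured pair differs in one place only, so the data give no direct reading of this change. With so few values, the expectation stays close to compound 2 at 71% in this assay and no firm direction can be claimed. The expected step is a number 2 percentage points higher from compound 2 to compound 3 (within the scatter) and it is not expected to go beyond the usual scatter. For compound 3 the estimated value is 73% with an expected range from 58% to 88% in this assay.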

Compound 3, percent of the compound remaining: 58%
Compound 3: the middle estimate sits 15 percentage points above what was measured; the range from low to high includes it.
By their numbers in this assay, from the lowest: compounds 3, 1 and 2 (each within the scatter of the next, the first and the last beyond it).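

In this assay the aromatic carbon of the five-membered aromatic ring with 3 nitrogen, between two ring nitrogen atoms, now has its first one-place reading: pyridazin-3-yl in place of thiophen-2-yl gives a number 13 percentage points lower from compound 2 to compound 3 (beyond the scatter) and this modest step lies beyond the usual scatter. The amount of compound left therefore depends on the group at this position, which compound 1 and compound 2 could not show, as they differ in more than one place. This reading rests on a single pair, and no measurement at hand says why the number moves.

From the compounds shown here alone, it remains open whether the step goes with the change from a five-membered to a six-membered aromatic ring or with the ring nitrogen atoms, a question that phenyl or pyridin-2-yl on the same carbon would help to separate. Also open, going by these compounds, is how a non-aromatic group at this position, such as the amine morpholin-4-yl, would read in this assay against thiophen-2-yl and pyridazin-3-yl.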